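This account rests on a few compounds, and the source may have more. Where it says the series, first, only, none or still open, it means among the compounds named here.

In a functional assay on PC-3 cells (Homo sapiens) for inhibition, read by MTT assay, with a stated time of 72 h (a lower number here means a stronger inhibitor, a higher number a weaker inhibitor), three related compounds have been measured so far. Compound 1 `CCC(=O)O[C@@H](/C(C)=C/[C@@H](C)c1oc(CC)c(C)c(=O)c1C)[C@H](C)[C@@H](OC(=O)CC(C)C)[C@@H](C)c1oc([C@@H](C)[C@@H](O)CC)c(C)c(=O)c1C` gives 3000 nM, and compound 2 `CCC(=O)[C@@H](C)c1oc([C@H](C)[C@@H]2O[C@](O)([C@@H](C)c3oc(CC)c(C)c(=O)c3C)[C@@H](C)[C@@H](O)[C@@H]2C)c(C)c(=O)c1C` gives 82000 nM. Compound 3 `CCC(=O)[C@H](C)c1oc([C@H](C)[C@@H]2O[C@](O)([C@@H](C)c3oc(CC)c(C)c(=O)c3C)[C@@H](C)[C@@H](O)[C@@H]2C)c(C)c(=O)c1C` gives > 100000 nM, which is a limit of the assay and not a number. Compound 3 is therefore known only through (the limit of > 100000 nM in this assay, at which 1 of the 3 values shown sits).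

Compound 4 `CCC(=O)[C@H](C)c1oc([C@H](C)[C@@H]2O[C@](O)([C@@H](C)c3oc(CC)c(C)c(=O)c3C)[C@@H](C)[C@@H](OC(=O)CC(C)C)[C@@H]2C)c(C)c(=O)c1C` comes from compound 3 by one change, isobutylcarbonyl in place of hydrogen on an oxygen on a saturated carbon, so that hydroxy becomes (isobutylcarbonyl)oxy.

Going by the values given here, the only measured step is an at least 1.2-fold higher number from compound 2 to compound 3 (0.08 log units; that floor lies within the scatter). It involves nothing more than the fact that compounds 2 and 3 differ only in the configuration as drawn, so it does not measure this kind of change. The one loose hint comes from compound 1, which also carries an (isobutylcarbonyl)oxy group and gives 3000 nM, a lower number than compound 2 with 82000 nM. Compound 1 differs from compound 2 in other places too, so this comparison cannot isolate the group.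

On that slim basis, a move towards stronger inhibition in this assay is expected, with wide uncertainty. The expected size of the change is an at least 10-fold lower number from compound 3 to compound 4 (1.00 log units; beyond the scatter). For compound 4 the estimated value is 10000 nM, with an expected range from 2000 nM to 50000 nM.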

Compound 4, half-maximal inhibitory concentration: 16000 nM
Beside the measured number, compound 4's estimate is 1.6-fold (0.20 log units) below it; measured number inside the range.
By their numbers in this assay, from the lowest: compound 1; then compound 4; then compound 2. At a limit, above all of these: compound 3.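

In this assay, going by these compounds alone, turning the hydroxy on this saturated ring carbon's oxygen into (isobutylcarbonyl)oxy gives the first step that changes only this group: an at least 6.2-fold lower number from compound 3 to compound 4 (0.79 log units; beyond the scatter). Within the data shown here, until now, the only single-place step concerned configuration, and the hint from compound 1 came with differences in other places, so neither could isolate this change. Here the ester-forming change alone goes with stronger inhibition, and the step lies beyond the usual scatter, but only its minimum size can be read, as compound 3 is known only through a limit of the assay: the limit of > 100000 nM in this assay, at which 1 of the 4 values shown sits.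

Going by these compounds, whether this effect belongs to isobutylcarbonyl in particular stays open, as does whether an acetyl group, a longer acyl chain or an acyl group carrying an amine on the same oxygen would lower the number as far, or further. Also open, on these data alone, is whether the same change made on compound 2, which differs from compound 3 in configuration at a saturated chain carbon, would give a step of similar size.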